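The source may report more compounds than this note shows. Statements on the series, on what has been measured and on what is new or still open speak of the compounds shown alone.

Compound 1 `COc1ccc(C(=O)/C=C/c2ccc(F)cc2)c2c1C=CC(C)(C)O2` was tested in a functional assay on SK-OV-3 cells (Homo sapiens) for antiproliferative activity, read by MTT assay, with a stated time of 24 h; a higher number here means a weaker inhibitor, a lower number a stronger inhibitor. Compound 1 gives > 10000 nM, which is a limit of the assay rather than a number. Compound 2 `COc1ccc(C(=O)/C=C/c2ccc(N3CCCC3)cc2)c2c1C=CC(C)(C)O2`, carrying a pyrrolidin-1-yl in place of fluoro on an aromatic carbon, gives 7370 nM in this assay. Going by the values given here, the step of an at least 1.3-fold lower number from compound 1 to compound 2 (0.13 log units; that floor lies within the scatter) is the only measured step, and its size is known only as a floor because one of its two values sits at the limit of > 10000 nM in this assay, at which 1 of the 2 values shown sits. Compound 3 `COc1ccc(C(=O)/C=C/c2cccc([N+](=O)[O-])c2)c2c1C=CC(C)(C)O2` is not yet measured. It differs from compound 1 by 3-nitrophenyl in place of 4-fluorophenyl on a double-bonded chain carbon bound to a double-bonded chain carbon. Among the compounds with values here, no measured step changes that group in the same way, and the one step that exists hardly moved the number, so little movement beyond the scatter is expected. The expected step is a step that the limit leaves unreadable from compound 1 to compound 3. Compound 3 is therefore estimated at 12000 nM, in a range from 5000 nM to 40000 nM, with a fair chance that only a limit is again reported.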

Compound 3, half-maximal inhibitory concentration: 9720 nM
For compound 3 the middle estimate is 1.2-fold (0.09 log units) above the measured one; measured number inside the range.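

In this assay compound 3 gives 9720 nM, a real number for a second kind of phenyl group on a double-bonded chain carbon bound to a double-bonded chain carbon. From the compounds shown here alone, exchanging 4-fluorophenyl for 3-nitrophenyl there gives an at least 1.0-fold lower number from compound 1 to compound 3 (0.01 log units; that floor lies within the scatter), so this change shows no movement beyond the scatter, although its true size remains unknown. That size is only a floor because compound 1 has a limit and not a number: the limit of > 10000 nM in this assay, at which 1 of the 3 values shown sits.

The compounds shown leave open whether the nitro group or its ring position counts more, as 4-nitrophenyl or 3-fluorophenyl at this place would change only one of the two. Also open, going by these compounds, is whether a carboxylic acid or a dimethylamino group on that phenyl ring would give a much lower number in this assay.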